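This account rests on a few compounds, and the source may have more. Where it says the series, first, only, none or still open, it means among the compounds named here.

Measured so far in a functional assay with Rattus norvegicus as the target; a higher number here means that more compound is needed for the effect, a lower number that less compound is needed:
Compound 1 `C[C@@H](/N=C(\S)NCc1ccc(C(C)(C)C)cc1)c1ccc([N+](=O)[O-])cc1`: > 100000 nM
Compound 2 `C[C@@H](/N=C(\S)NCc1ccc(C(C)(C)C)cc1)c1ccccc1`: > 100000 nM

Compound 2 gives > 100000 nM, and this is a limit of the assay, not a number. Compound 1 gives > 100000 nM, which is likewise a limit. The whole picture so far is the limit of > 100000 nM in this assay, at which 2 of the 2 values shown sit.

Compound 3 `C[C@@H](/N=C(\S)NCc1ccc(C(C)(C)C)cc1)c1ccc(C(C)(C)C)cc1` departs from compound 2 in one place: tert-butyl in place of hydrogen on an aromatic carbon. The new group is a tert-butyl in place of hydrogen on an aromatic carbon, para to a large group. Among the compounds with values here, the only measured step that bears on this is a step that the two limits leave unreadable from compound 1 to compound 2, which also concerns a group on an aromatic carbon. That step offers no size to carry over, so the data hold no measured effect of a change of this kind. In this assay the expectation is therefore no step beyond the scatter, in neither direction, and a report of only a limit is the likeliest outcome. The expected step is a number no higher from compound 2 to compound 3 (the limit leaves the size open). For compound 3 the estimated value is 100000 nM, with an expected range from 30000 nM to 200000 nM.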

Compound 3, half-maximal effective concentration: > 100000 nM
Compound 3 gave a limit, no number; the forecaster's own chance of this, stated with the estimate: 80%; the middle value sits exactly at the limit.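

In this assay compound 3 gives > 100000 nM, a limit of the assay and not a number. No step between compound 3 and compound 1 or compound 2 can be read, and the whole picture remains: the limit of > 100000 nM in this assay, at which 3 of the 3 values shown sit.

The compounds shown leave open whether any group on this aromatic carbon yields a measurable value in this assay.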